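Para-substituent variation on the shared core: triazolyl to carboxypyridinyl

The compounds below may be only part of what the source reports. "The series", "measured", "known", "first", "only" and "open" are said of these compounds alone.

Measured so far in a functional assay on HEK293 cells for agonist activity at Bombesin receptor subtype-3 (Mus musculus), read by luminescence and calcium flux, with a stated time of 10 min; a lower number here means that less compound is needed, a higher number that more compound is needed for the effect:
compound 1, `CCC(C)(C)Cc1c[nH]c(CCc2ccc(-c3cccc(N)n3)cc2)n1`, 119 nM
compound 2, `CCC(C)(C)Cc1c[nH]c(CCc2ccc(N3CCCCC3)cc2)n1`, 133 nM
compound 3, `CCC(C)(C)Cc1c[nH]c(CCc2ccc(-n3ccnn3)cc2)n1`, 111 nM

Compound 3 carries the lowest of the three numbers, yet its gaps to compound 1 and compound 2 both fall within the scatter, so no order among the three can be claimed.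

Compound 4, `CCC(C)(C)Cc1c[nH]c(CCc2ccc(-c3cccnc3C(=O)O)cc2)n1`, differs from compound 3 as follows. 2-carboxypyridin-3-yl in place of 1H-1,2,3-triazol-1-yl on an aromatic carbon

For the measured compounds named here, the steps that bear on this position are a 1.1-fold lower number from compound 1 to compound 3 (0.03 log units; within the scatter) and a 1.2-fold lower number from compound 2 to compound 3 (0.08 log units; within the scatter), each within the scatter; three quite different groups at this carbon therefore gave indistinguishable numbers. Compound 1, with its own six-membered aromatic ring containing one nitrogen at the same place, gives 119 nM. The estimate for compound 4 is accordingly a step of a 1.2-fold higher number from compound 3 to compound 4 (0.09 log units; within the scatter), no more than the scatter, expected to land near 135 nM within 45 nM to 400 nM.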

Compound 4, half-maximal effective concentration: 97 nM
Beside the measured number, compound 4's estimate is 1.4-fold (0.14 log units) above it; low and high end bracket the measured number.
By their numbers in this assay, from the lowest: compounds 4, 3, 1 and 2 (each within the scatter of the next).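

For the compounds shown here, the 2-carboxypyridin-3-yl group puts a carboxylic acid on this aromatic carbon for the first time, and the steps are a 1.1-fold lower number from compound 3 to compound 4 (0.06 log units; within the scatter) and a 1.2-fold lower number from compound 1 to compound 4 (0.09 log units; within the scatter) and a 1.4-fold lower number from compound 2 to compound 4 (0.14 log units; within the scatter). Across these four compounds, no order can be claimed among the groups at this carbon. No evidence on hand accounts for this result.

From the compounds shown here alone, whether a primary amide or a methyl ester in place of the carboxylic acid would also stay within the scatter remains open. Also open, going by these compounds, is whether any group at this carbon moves the number beyond it.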